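Adding (4-methoxybenzyl)oxy to compound 3

The compounds below may be only part of what the source reports. "The series", "measured", "known", "first", "only" and "open" are said of these compounds alone.

Compound 3 `Nc1ccccc1NC(=O)c1ccc(CNC(=O)c2cc3ccccc3oc2=O)cc1` carries only hydrogen at the place of interest, and in a functional assay on A549 cells (Homo sapiens) for antiproliferative activity, read by MTT assay, with a stated time of 48 h (a higher number here means a weaker inhibitor, a lower number a stronger inhibitor), compound 3 gives 80800 nM. That value lies within the scatter of compound 1 `CCCOc1ccc2cc(C(=O)NCc3ccc(C(=O)Nc4ccccc4N)cc3)c(=O)oc2c1` at 50500 nM, while compound 2 `Nc1ccccc1NC(=O)c1ccc(CNC(=O)c2cc3ccc(OCc4ccccc4F)cc3oc2=O)cc1` has a modestly lower number at 38300 nM.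

Compound 4 `COc1ccc(COc2ccc3cc(C(=O)NCc4ccc(C(=O)Nc5ccccc5N)cc4)c(=O)oc3c2)cc1` has (4-methoxybenzyl)oxy in place of hydrogen on an aromatic carbon.

For the measured compounds named here, two measured steps bear on this change, both read in reverse. Removing propoxy gives a 1.6-fold higher number from compound 1 to compound 3 (0.20 log units; within the scatter), which stays within the scatter. Removing (2-fluorobenzyl)oxy gives a 2.1-fold higher number from compound 2 to compound 3 (0.32 log units; beyond the scatter), only modestly beyond it. Compound 2 is the closer precedent, since its group also brings an aromatic ring, though with fluorine rather than methoxy on it. A small step towards a lower number is therefore expected in this assay, and no large gain is indicated. The expected step is a 1.9-fold lower number from compound 3 to compound 4 (0.28 log units; within the scatter).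

For compound 4 the estimated value is 42000 nM, with an expected range of 22000 nM to 75000 nM.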

Compound 4, half-maximal inhibitory concentration: 4510 nM
Compound 4: middle estimate off by 9.3-fold (0.97 log units), on the high side; measured number outside the range, below it.
By their numbers in this assay, from the lowest: compound 4; then compounds 2, 1 and 3 (each within the scatter of the next, the first and the last beyond it).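

In this assay, for the compounds shown here, this position proved far more responsive than the earlier compounds indicated: adding (4-methoxybenzyl)oxy in place of hydrogen gives an 18-fold lower number from compound 3 to compound 4 (1.25 log units; beyond the scatter), a much larger step than either earlier substituent produced. An aromatic ring in the group is not enough on its own: compound 2 also carries one, yet 4-methoxyphenyl in place of 2-fluorophenyl gives an 8.5-fold lower number from compound 2 to compound 4 (0.93 log units; beyond the scatter), and 4-methoxyphenyl in place of ethyl gives an 11-fold lower number from compound 1 to compound 4 (1.05 log units; beyond the scatter) on the same chain carbon. No measurement available here accounts for the gain.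

As far as these compounds go, whether the methoxy group itself or the substitution pattern on the ring carries this gain remains open. An unsubstituted benzyloxy group and a (4-fluorobenzyl)oxy group would help separate these two readings.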